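The source may hold more compounds than are shown below. What is called first, only, known or untested is meant among the compounds shown, and "the series" means these compounds.

Working notes on the series. Compound 2 `Cn1cnnc1SCC(=O)N/N=c1/scc(-c2ccccc2)n1-c1ccccc1` gives, in a functional assay on C6 cells (Rattus norvegicus) for cytotoxicity, read by MTT assay, with a stated time of 24 h, tested at 50 ug/mL (on this read-out higher numbers stand for a weaker effect at the one concentration tested and lower numbers for a stronger effect), a reading of 62.4%, the highest of the two numbers in hand. Compound 1 `Cc1ccc(-c2cs/c(=N/NC(=O)CSc3nnnn3C)n2-c2ccccc2)cc1`, which does not share the change discussed next, gives 44.3% in this assay, a gap beyond the scatter. Compound 3 `Cn1nnnc1SCC(=O)N/N=c1/scc(-c2ccccc2)n1-c1ccccc1` is not yet measured; it differs from compound 2 by 1-methyl-1H-tetrazol-5-yl in place of 4-methyl-4H-1,2,4-triazol-3-yl on a sulfur. Within the data shown here, no measured pair carries this change, so the expected step of a number 4.4 percentage points lower from compound 2 to compound 3 (within the scatter) is small, within the scatter, with no direction claimed. Compound 3 is therefore estimated at 58%, with a range of 40% to 76%.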

Compound 3, a percentage reported as activity, at one concentration (the size of the read-out at that concentration, not a potency): 56.2%
Compound 3: the middle estimate sits 1.8 percentage points above what was measured; the range from low to high includes it.
By their numbers in this assay, from the lowest: compound 1; then compounds 3 and 2 (each within the scatter of the next).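

On a sulfur, 1-methyl-1H-tetrazol-5-yl in place of 4-methyl-4H-1,2,4-triazol-3-yl now has a measured pair in this assay and reads a number 6.2 percentage points lower from compound 2 to compound 3 (within the scatter) for this change, so the two groups are not separated here. Hydrogen in place of methyl on an aromatic carbon reads a number 11.9 percentage points higher from compound 1 to compound 3 (beyond the scatter) and is the only one-place step so far that lies beyond the scatter, though modestly. Nothing in hand bears on the cause of either step.

As far as these compounds go, it remains open whether the methyl step carries over to compounds holding 4-methyl-4H-1,2,4-triazol-3-yl on the sulfur. From the compounds shown here alone, how an amine or a carboxylic acid on that aromatic carbon would read also remains open.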